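This account rests on a few compounds, and the source may have more. Where it says the series, first, only, none or still open, it means among the compounds named here.

Series notes. In a functional assay for inhibition, with Homo sapiens as the target (on this read-out lower numbers stand for stronger inhibition and higher numbers for weaker inhibition), compound 1 `CCCc1nc(C)c2cnnc(O)n12` gives 56800 nM, the higher of the two numbers; compound 2 `CCCc1nc(C)c2ccnc(Nc3cc[nH]n3)n12` gives 25000 nM. The difference between the two cores is not broken down here. For compound 3 `CCCc1cnc(Nc2cc[nH]n2)n2c(CCC)nc(C)c12` this assay reports only a limit, > 48000 nM. The change propyl in place of hydrogen on an aromatic carbon thus gives an at least 1.9-fold higher number from compound 2 to compound 3 (0.28 log units; that floor lies within the scatter), a floor only because of the limit of > 48000 nM in this assay, at which 1 of the 3 values shown sits.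

Compound 4 `CCCc1nnc(O)n2c(CCC)nc(C)c12` carries the same kind of change on the core of compound 1, (propyl in place of hydrogen on an aromatic carbon); the place differs in that the six-membered aromatic ring holds 3 nitrogen, the propyl sits next to the ring nitrogen and para to a hydroxy group rather than para to a (1H-pyrazol-3-yl)amino group. For compound 4 the expected step is a 1.9-fold higher number from compound 1 to compound 4 (0.29 log units; within the scatter), resting on an at least 1.9-fold higher number from compound 2 to compound 3 (0.28 log units; that floor lies within the scatter). Compound 4 is estimated at 110000 nM, between 50000 nM and 250000 nM, and a limit is likely.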

Compound 4, half-maximal inhibitory concentration: 16000 nM
For compound 4 the middle estimate is 6.9-fold (0.84 log units) above the measured one; the measured number lies below the stated range.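

In this assay, propyl in place of hydrogen on an aromatic carbon gives a 3.6-fold lower number from compound 1 to compound 4 (0.55 log units; beyond the scatter). This change therefore does not carry over between the two cores as one transferable step: the same change on two cores in this assay, an at least 1.9-fold higher number (0.28 log units; that floor lies within the scatter) from compound 2 to compound 3 and a 3.6-fold lower number (0.55 log units; beyond the scatter) from compound 1 to compound 4, at least 6.8-fold (0.83 log units) apart, beyond the scatter of two such steps

The pairs do not show which difference between the cores goes with the change in direction, and the true size of the step on the other core remains unknown: the limit of > 48000 nM in this assay, at which 1 of the 4 values shown sits.

Open, from the compounds shown here alone, is whether a shorter chain such as ethyl, or a longer one such as butyl, on the same aromatic carbon of the core of compound 1 would follow propyl. Also open, going by these compounds, is whether an amine there would give a step in the same direction.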